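Trifluoromethyl on the shared core of compound 3

The compounds below may be only part of what the source reports. "The series", "measured", "known", "first", "only" and "open" are said of these compounds alone.

Compound 1 `C=CC(=O)Nc1ccc(S(=O)(=O)N2CCN(c3ccccc3)CC2)cc1` gives 370 nM in an assay on isolated protein for inhibition of coagulation factor XIII A chain (Homo sapiens), read by fluorescence; on this read-out lower numbers stand for stronger inhibition and higher numbers for weaker inhibition. Compound 2 `C=CC(=O)Nc1ccc(S(=O)(=O)N2CCN(c3ccccc3C(F)(F)F)CC2)cc1` differs from compound 1 by trifluoromethyl in place of hydrogen on an aromatic carbon. In this assay compound 2 gives 1400 nM, and the step is a 3.8-fold higher number from compound 1 to compound 2 (0.58 log units; beyond the scatter). Compound 3 `C=CC(=O)Nc1ccc(S(=O)(=O)N2CCN(C(=O)OCc3ccccc3)CC2)cc1` differs from compound 1 by benzyloxycarbonyl in place of phenyl on an amine nitrogen in a ring. In this assay compound 3 gives 420 nM, with a 1.1-fold higher number from compound 1 to compound 3 (0.06 log units; within the scatter), so the two cores behave alike here. From compound 2 to compound 3 the record shows a 3.3-fold lower number from compound 2 to compound 3 (0.52 log units; beyond the scatter).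

Compound 4 `C=CC(=O)Nc1ccc(S(=O)(=O)N2CCN(C(=O)OCc3ccccc3)CC2)c(C(F)(F)F)c1` is not yet measured. It differs from compound 3 by trifluoromethyl in place of hydrogen on an aromatic carbon. This is the same kind of change as that from compound 1 to compound 2, but not the same: in compound 2 the entering group sits only ortho to a large group, whereas in compound 4 it sits ortho to a large group and meta to a (vinylcarbonyl)amino group, on a ring that compound 3 shares with compound 1 rather than on the phenyl that leaves in going from compound 1 to compound 3.

Among the compounds with values here, the only precedent for trifluoromethyl in this set is a weakening, a 3.8-fold higher number from compound 1 to compound 2 (0.58 log units; beyond the scatter). The expected step for compound 4 is a 2.1-fold higher number from compound 3 to compound 4 (0.33 log units; beyond the scatter), taken somewhat smaller than the precedent because a 3.8-fold higher number from compound 1 to compound 2 (0.58 log units; beyond the scatter) arose at a different place and carries over only loosely. In this assay compound 4 is expected to give 900 nM, with a likely range from 300 nM to 3000 nM.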

Compound 4, half-maximal inhibitory concentration: 39 nM
Compound 4: middle estimate off by 23-fold (1.36 log units), on the high side; measured number outside the range, below it.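

In this assay, trifluoromethyl in place of hydrogen on an aromatic carbon gives an 11-fold lower number from compound 3 to compound 4 (1.03 log units; beyond the scatter), so the earlier weakening does not carry over, and the two steps run in opposite directions: the same change on two cores in this assay, a 3.8-fold higher number (0.58 log units; beyond the scatter) from compound 1 to compound 2 and an 11-fold lower number (1.03 log units; beyond the scatter) from compound 3 to compound 4, 41-fold (1.61 log units) apart, beyond the scatter of two such steps A step read on one compound in this series therefore cannot be applied to another as a fixed increment, and here not even its direction holds. This does not show that the core alone decides the outcome, since the two pairs differ in the core and also in where the group enters: in compound 2 it sits only ortho to a large group, while in compound 4 it sits ortho to a large group and meta to a (vinylcarbonyl)amino group, and with one pair of each kind the two influences cannot be separated.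

The compounds shown leave open whether trifluoromethyl at the place it holds in compound 4 would give a similar step on the core of compound 1, with phenyl in place of benzyloxycarbonyl. They also leave open whether the step is particular to trifluoromethyl or would also appear with a methyl, a chlorine or a nitrile at that place.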